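From 2-Methoxyethoxy to Butylamino: Expected Cytotoxicity

The source may hold more compounds than are shown below. What is called first, only, known or untested is meant among the compounds shown, and "the series" means these compounds.

Compound 1 `COCCOC(=O)Nc1cc2nc(C3CCCCC3)[nH]c2cc1N1CCCC1` gives > 100 ug/mL in an ADME assay on Vero cells (Chlorocebus sabaeus) for cytotoxicity, read by resazurin assay, with a stated time of 3 days; a higher number here means a weaker inhibitor, a lower number a stronger inhibitor.
Compound 2 `CCCCOC(=O)Nc1cc2nc(C3CCCCC3)[nH]c2cc1N(C)CCN(C)C` gives > 100 ug/mL in this assay.
Compound 3 `CN(C)c1cc2[nH]c(C3CCCCC3)nc2cc1NC(=O)c1ccc(OC(F)(F)F)cc1` gives > 100 ug/mL in this assay.

Each of these three values is a limit of the assay rather than a measured number. Compound 1 therefore stands exactly where the other two measured compounds stand, namely at the limit of > 100 ug/mL in this assay, at which 3 of the 3 values shown sit. Going by the values given here, no pair among compounds 1, 2 and 3 differs in only one place, so no measured step exists from which a direction could be read; the three results simply agree with one another.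

Compound 4 `CCCCNC(=O)Nc1cc2nc(C3CCCCC3)[nH]c2cc1N1CCCC1` differs from compound 1 by a single change: butylamino in place of 2-methoxyethoxy on a carbonyl carbon. With all three measured compounds sitting at the same limit, the step that the limit leaves unreadable from compound 1 to compound 4 is expected to be none beyond the usual scatter, in either direction. Compound 4 is accordingly estimated at 150 ug/mL, with a range from 60 ug/mL to 400 ug/mL, and the most likely outcome is that the assay again reports only a limit for compound 4.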

Compound 4, half-maximal inhibitory concentration: > 100 ug/mL
Compound 4: a limit, no number; the forecaster's own chance of this, stated with the estimate: 80%; the middle value is on the limit's open side.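

Going by these compounds alone, compound 1 and compound 4 each give only a limit in this assay, not a number, so no step between them can be read. The compounds shown leave open the cytotoxic concentration of each compound, and whether butylamino and 2-methoxyethoxy differ at all on that carbonyl carbon: the limit of > 100 ug/mL in this assay, at which 4 of the 4 values shown sit.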